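The source may hold more compounds than are shown below. What is called first, only, known or untested is meant among the compounds shown, and "the series" means these compounds.

Measured in a functional assay on MCF7 cells (Homo sapiens) for cytotoxicity, read by MTT assay, with a stated time of 48 h; a higher number here means a weaker inhibitor of growth, a lower number a stronger inhibitor of growth:
compound 1 `FC(F)(F)c1nc2cc(Cl)c(Cl)cc2n1C1CCCC1`: 21000 nM
compound 2 `CC(C)c1nc2cc(Cl)c(Cl)cc2n1C1CCCC1`: 43000 nM
compound 3 `C[S+]([O-])c1nc2cc(Cl)c(Cl)cc2n1C1CCCC1`: 500 nM

Compound 3 has the lowest number of the three and is the strongest inhibitor of growth here, with a 42-fold lower number from compound 1 to compound 3 (1.62 log units; beyond the scatter) and an 86-fold lower number from compound 2 to compound 3 (1.93 log units; beyond the scatter), both large. Compound 4 `CS(=O)(=O)c1nc2cc(Cl)c(Cl)cc2n1C1CCCC1` keeps the shared core and alters only the group on the aromatic carbon between two ring nitrogen atoms: a group of 4 heavy atoms (1 carbon, 2 oxygen, 1 sulfur; no ring) in place of a group of 3 heavy atoms (1 carbon, 1 oxygen, 1 sulfur; no ring), on an aromatic carbon. The entering group is methylsulfonyl.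

Going by the values given here, no measured step makes this exact change. The group in compound 3 stands apart from trifluoromethyl and isopropyl, while the step between those two is only modest, a 2.0-fold higher number from compound 1 to compound 2 (0.31 log units; beyond the scatter). Compound 4 also carries carbon, oxygen and sulfur in this group, so a modest rise in this assay is expected rather than a large one, although an 86-fold lower number from compound 2 to compound 3 (1.93 log units; beyond the scatter) shows that a change at this carbon can be large.

The expected change is a 2.0-fold higher number from compound 3 to compound 4 (0.30 log units; within the scatter). The estimate for compound 4 is 1000 nM, with an expected range of 200 nM to 8000 nM.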

Compound 4, concentration for 50% growth inhibition: 600 nM
The estimate for compound 4 lay 1.7-fold (0.22 log units) above the measured number; low and high end bracket the measured number.
By their numbers in this assay, from the lowest: compounds 3 and 4 (each within the scatter of the next); then compound 1; then compound 2.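

Working notes on the group on the aromatic carbon between two ring nitrogen atoms, read in this assay: the change to methylsulfonyl cannot be told apart from the scatter (a 1.2-fold higher number from compound 3 to compound 4 (0.08 log units; within the scatter)). The large distance from the non-sulfur groups is therefore not unique to compound 3, since it also appears with methylsulfonyl, against isopropyl (a 72-fold lower number from compound 2 to compound 4 (1.86 log units; beyond the scatter)) and against trifluoromethyl (a 35-fold lower number from compound 1 to compound 4 (1.54 log units; beyond the scatter)). Nothing on hand accounts for compounds 3 and 4 reading alike.

Still open, from the compounds shown here alone, is whether sulfur itself is needed at this carbon, or whether a methylthio group, an amine or a carboxylic acid would read like compounds 3 and 4. Going by these compounds, the cyclopentyl group is the same in all four compounds, so its contribution to these numbers also remains unknown.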